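The source may report more compounds than this note shows. Statements on the series, on what has been measured and on what is new or still open speak of the compounds shown alone.

Measured so far:
compound 1 `CCCc1cc(N)c2cc(NC(=O)/C=C/c3ccc(CC)cc3)ccc2n1` — 160 nM
compound 2 `CCCc1cc(N)c2cc(NC(=O)/C=C/c3ccc(I)cc3)ccc2n1` — 280 nM

Both compounds share one core and differ only at the group on the aromatic carbon of the terminal ring. In a functional assay on HEK293 cells for activation of melanin-concentrating hormone receptor 1 (Homo sapiens), read by inositol phosphate accumulation (a lower number here means that less compound is needed, a higher number that more compound is needed for the effect), compound 1 gives 160 nM. In this assay compound 2 gives 280 nM. Among the measured compounds shown here, compound 2 stands beside compound 1 with no separation to speak of: the only measured step, a 1.8-fold higher number from compound 1 to compound 2 (0.24 log units; within the scatter), is within the scatter, so the two numbers are read as one level.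

Compound 3 `CCCc1cc(N)c2cc(NC(=O)/C=C/c3ccc(Cl)cc3)ccc2n1` is not yet measured in this assay. For the measured compounds named here, it differs from compound 2 by chloro in place of iodo on an aromatic carbon, a change at the same place that the one measured step touched. Going by the values given here, no measured step exchanges iodo for chloro directly; the only step that bears on this position, a 1.8-fold higher number from compound 1 to compound 2 (0.24 log units; within the scatter), exchanged ethyl for iodo and stayed within the scatter. On that basis no step beyond the scatter is expected from compound 2 to compound 3, and the estimate is a step of a 1.1-fold higher number from compound 2 to compound 3 (0.03 log units; within the scatter). For compound 3 the expected value in this assay is 300 nM, with a range from 120 nM to 750 nM.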

Compound 3, half-maximal effective concentration: 96 nM
Beside the measured number, compound 3's estimate is 3.1-fold (0.49 log units) above it, outside the stated range (below it).
By their numbers in this assay, from the lowest: compounds 3, 1 and 2 (each within the scatter of the next, the first and the last beyond it).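

In this assay, among the compounds shown here, the exchange of 4-iodophenyl for 4-chlorophenyl gives a 2.9-fold lower number from compound 2 to compound 3 (0.46 log units; beyond the scatter), the first step to pass the scatter, so this position is not as flat as the exchange of ethyl for iodo alone suggested. The other new step, a 1.7-fold lower number from compound 1 to compound 3 (0.22 log units; within the scatter), stays within the scatter, so chloro and ethyl read as one level. Ethyl and iodo also read as one level. The three compounds form a chain in which only the two ends, the chloro and iodo compounds, separate, and the size of that separation is modest. No measurement at hand accounts for the difference between chloro and iodo at this carbon.

It remains open how far the trend among these three groups extends, since fluoro, bromo, methoxy, an amine or a carboxylic acid on this aromatic carbon would test whether the difference between chloro and iodo belongs to the halogens alone or to a broader dependence on the group. Also open, going by these compounds, is whether chloro keeps its standing against iodo when the propyl chain or the free amine of the shared core is replaced, for example by a longer chain or an amide.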